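The source may hold more compounds than are shown below. What is called first, only, known or untested is meant among the compounds shown, and "the series" means these compounds.

Measured compounds:
compound 1 `COc1ccc(S(=O)(=O)N2CCc3cccc(NC(=O)c4ccc([N+](=O)[O-])cc4)c32)cc1` — 95 nM
compound 2 `COc1ccc(S(=O)(=O)N2CCc3cccc(NC(=O)c4ccncc4)c32)cc1` — 8.9 nM
compound 3 `COc1ccc(S(=O)(=O)N2CCc3cccc(NCc4ccccc4)c32)cc1` — limit, > 10000 nM

In a functional assay on KB cells (Homo sapiens) for cytotoxicity (a lower number here means a stronger inhibitor, a higher number a weaker inhibitor), compound 1 gives 95 nM, the highest of the two numbers recorded; the nearest is compound 2, reached by an 11-fold lower number from compound 1 to compound 2 (1.03 log units; beyond the scatter). Compound 3 sits at a limit of this assay rather than a number, (the limit of > 10000 nM in this assay, at which 1 of the 3 values shown sits). The step there is an at least 1100-fold higher number from compound 2 to compound 3 (3.05 log units; beyond the scatter).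

Compound 4 `COc1ccc(S(=O)(=O)N2CCc3cccc(NC(C)=O)c32)cc1` has not yet been measured in this assay. Its change from compound 1 is methyl in place of 4-nitrophenyl on a carbonyl carbon. Going by the values given here, two measured steps bear on it. The step from compound 1 to compound 2 shows that the group on the carbonyl carbon moves the number by a large amount, and the step from compound 2 to compound 3 shows that removing the aromatic carbonyl substituent altogether carries the number to the limit. Since compound 4 keeps the carbonyl but loses the aromatic ring, a large step toward a higher number, beyond the scatter, is expected, though not necessarily as far as the limit. Compound 4 is therefore estimated at 1500 nM, within 250 nM to 9000 nM, which is the expected step of a 16-fold higher number from compound 1 to compound 4 (1.20 log units; beyond the scatter).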

Compound 4, half-maximal inhibitory concentration: 90 nM
Beside the measured number, compound 4's estimate is 17-fold (1.22 log units) above it; the measured number lies below the stated range.
By their numbers in this assay, from the lowest: compound 2; then compounds 4 and 1 (each within the scatter of the next). At a limit, above all of these: compound 3.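

In this assay, methyl can replace 4-nitrophenyl on the carbonyl carbon without a change beyond the scatter: a 1.1-fold lower number from compound 1 to compound 4 (0.02 log units; within the scatter). An aromatic ring on this carbonyl is therefore not required for a value of this order, yet the group there is not indifferent, as pyridin-4-yl stands apart with a 10-fold higher number from compound 2 to compound 4 (1.00 log units; beyond the scatter). The carbonyl itself counts for more than the ring in this set, since acetyl in place of benzyl on the nitrogen gives an at least 110-fold lower number from compound 3 to compound 4 (2.04 log units; beyond the scatter), a step read against a limit and not a number, at which compound 3 stands: the limit of > 10000 nM in this assay, at which 1 of the 4 values shown sits.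

Going by these compounds, whether an unsubstituted phenyl, a pyridin-3-yl or a longer chain such as butyl on the carbonyl carbon would read with compound 2 or with compound 4 stays open. Also open, on these data alone, is whether an amine or a carboxylic acid on that ring would keep the value of compound 2.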